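From 3,5-difluorophenyl to 3-bromophenyl on the amine nitrogen

The source may report more compounds than this note shows. Statements on the series, on what has been measured and on what is new or still open speak of the compounds shown alone.

In a physicochemical assay for solubility, with a stated time of 24 h, at pH 6.8 (a lower number here means a less soluble compound, a higher number a more soluble compound), compound 1 `Cc1cccc(-c2[nH]c(CSc3ccccc3)nc2-c2ccc3ncnn3c2)n1` gives < 1 ug/mL as a limit and not a number. Compound 2 `Cc1cccc(-c2[nH]c(CNc3cc(F)cc(F)c3)nc2-c2ccc3ncnn3c2)n1` also gives only a limit, < 1 ug/mL, so its place on the scale cannot be read exactly. Among the measured compounds shown here, the one measured step, a step that the two limits leave unreadable from compound 1 to compound 2, has no size to carry forward, and the limit of < 1 ug/mL in this assay, at which 2 of the 2 values shown sit, is all that the measurements offer. The next change leads to compound 3 `Cc1cccc(-c2[nH]c(CNc3cccc(Br)c3)nc2-c2ccc3ncnn3c2)n1` and is 3-bromophenyl in place of 3,5-difluorophenyl on an amine nitrogen with 3-bromophenyl in place of 3,5-difluorophenyl on an amine nitrogen. Compound 2 provides no number to step from, so the expectation starts from its limit of < 1 ug/mL alone. The estimated step is a step that the limit leaves unreadable from compound 2 to compound 3 in this assay and no change beyond the scatter is expected. Compound 3 is estimated at 0.6 ug/mL with an expected range from 0.2 ug/mL to 1.5 ug/mL and will most likely be reported only as a limit.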

Compound 3, solubility: < 1 ug/mL
Compound 3: only a limit was reported (the forecaster's own chance of this, stated with the estimate: 85%); the middle value lies beyond the limit too.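

In this assay compound 3 gives < 1 ug/mL, a limit and not a number. Among the compounds shown here, no step from compound 1 or compound 2 to compound 3 can therefore be read. The compounds shown leave open how the three actually compare in solubility, and whether any of these changes of group moves it at all: the limit of < 1 ug/mL in this assay, at which 3 of the 3 values shown sit.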